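Benzothiazolyl for methylbenzoxazolyl on the sulfanyl side chain

This account rests on a few compounds, and the source may have more. Where it says the series, first, only, none or still open, it means among the compounds named here.

Measured in a functional assay on HT-29 cells (Homo sapiens) for cytotoxicity, read by MTT assay, with a stated time of 24 h, tested at 6.4 ug/mL; a lower number here means a weaker effect, a higher number a stronger effect of the compound at the concentration tested:
compound 1 `Cn1c(-c2ccc(NC(=O)CCl)cc2)nc(-c2ccccc2)c1-c1ccccc1` gives 15.1%
compound 2 `Cc1ccc2oc(SCC(=O)Nc3ccc(-c4nc(-c5ccccc5)c(-c5ccccc5)n4C)cc3)nc2c1` gives 25.6%

For the measured compounds named here, compound 2 stands highest of the two numbers; the one step measured so far is a number 10.5 percentage points higher from compound 1 to compound 2 (beyond the scatter). Compound 3 `Cn1c(-c2ccc(NC(=O)CSc3nc4ccccc4s3)cc2)nc(-c2ccccc2)c1-c1ccccc1` differs from compound 2 by 1,3-benzothiazol-2-yl in place of 5-methyl-1,3-benzoxazol-2-yl on a sulfur. Going by the values given here, no measured step exchanges one such heteroaryl for another, so that step offers no direct guide. The step from compound 2 to compound 3 is therefore expected to be a number 0.6 percentage points lower from compound 2 to compound 3 (within the scatter), not beyond the scatter. Compound 3 is estimated at 25%, with a range from 12% to 40%.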

Compound 3, a percentage reported as activity, at one concentration (the size of the read-out at that concentration, not a potency): 36.8%
The estimate for compound 3 lay 11.8 percentage points below the measured number; low and high end bracket the measured number.
By their numbers in this assay, from the lowest: compound 1; then compound 2; then compound 3.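

In this assay the heteroaryl on the sulfur matters in its own right, since the exchange of 5-methyl-1,3-benzoxazol-2-yl for 1,3-benzothiazol-2-yl moves the read-out (a number 11.2 percentage points higher from compound 2 to compound 3 (beyond the scatter)). Replacing chloro with (1,3-benzothiazol-2-yl)sulfanyl gives the largest step in the series (a number 21.7 percentage points higher from compound 1 to compound 3 (beyond the scatter)). Nothing available explains this difference.

The exchange changes oxygen to sulfur and removes the methyl together, so an unsubstituted 1,3-benzoxazol-2-yl would be needed to separate the two. Going by these compounds, how an amine on the same chain carbon would compare also stays open.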